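The source may hold more compounds than are shown below. What is called first, only, known or untested is meant among the compounds shown, and "the series" means these compounds.

Working notes, series read in a functional assay on HT-29 cells (Homo sapiens) for inhibition, read by MTT assay, with a stated time of 48 h; on this read-out lower numbers stand for stronger inhibition and higher numbers for weaker inhibition:
- compound 1 `COc1cc(-c2cc(-c3cccc(O)c3)nc(-c3ccccc3)n2)cc(OC)c1OC`: > 25000 nM (a limit of the assay, not a number)
- compound 2 `COc1cc(-c2cc(-c3ccc(O)cc3)nc(-c3ccccc3)n2)cc(OC)c1OC`: 11300 nM
- compound 3 `COc1cc(-c2cc(-c3ccc(O)cc3O)nc(-c3ccccc3)n2)cc(OC)c1OC`: 4960 nM

Of the two true numbers, compound 3 holds the lower, and compound 2 is its nearest neighbour. The next structure, compound 4 `COc1cc(-c2cc(-c3cccc4ccccc34)nc(-c3ccccc3)n2)cc(OC)c1OC`, carries naphthalen-1-yl in place of 2,4-dihydroxyphenyl on an aromatic carbon. For the measured compounds named here, no measured compound has an aryl group without hydroxy, so the evidence is indirect. The closest guide is the single added hydroxy, which gave a 2.3-fold lower number from compound 2 to compound 3 (0.36 log units; beyond the scatter). Moving or adding hydroxy also lowered the number, with an at least 2.2-fold lower number from compound 1 to compound 2 (0.34 log units; beyond the scatter) and an at least 5.0-fold lower number from compound 1 to compound 3 (0.70 log units; beyond the scatter), though both of these rest on a limit. All three steps are modest and favour hydroxy-bearing aryl groups, so a modest rise in this assay is expected on losing both hydroxy groups. The estimated step is a 2.2-fold higher number from compound 3 to compound 4 (0.35 log units; beyond the scatter). For compound 4 the expected value is 11000 nM, with an estimated range of 3500 nM to 25000 nM.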

Compound 4, half-maximal inhibitory concentration: 4730 nM
The estimate for compound 4 lay 2.3-fold (0.37 log units) above the measured number; the measured number falls inside the stated range.
By their numbers in this assay, from the lowest: compounds 4 and 3 (each within the scatter of the next); then compound 2. At a limit, above all of these: compound 1.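

In this assay, hydroxy on the aryl group at this position is not needed for a low number: naphthalen-1-yl, with no hydrogen-bond donors, replaces 2,4-dihydroxyphenyl with a 1.0-fold lower number from compound 3 to compound 4 (0.02 log units; within the scatter). For the compounds shown here, a group without hydroxy also gives a 2.4-fold lower number from compound 2 to compound 4 (0.38 log units; beyond the scatter), so the preference for hydroxy-bearing aryl groups seen among the earlier compounds does not extend to compound 4. The step of an at least 5.2-fold lower number from compound 1 to compound 4 (0.72 log units; beyond the scatter) rests on the value of compound 1, which is a limit of the assay and not a number: the limit of > 25000 nM in this assay, at which 1 of the 4 values shown sits.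

The compounds shown do not separate the effect of the second aromatic ring in compound 4 from that of losing both hydroxy groups. From the compounds shown here alone, how an aryl group carrying an amine or a carboxylic acid would read at this position remains open.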